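The compounds below may be only part of what the source reports. "The series", "measured", "known", "first", "only" and "open" are said of these compounds alone.

Measured so far:
Compound 1, `O=C(CSc1nnc(-c2ccncc2)o1)N/N=C/c1ccc(O)cc1`: 12200 nM
Compound 2, `Cc1ccc(/C=N/NC(=O)CSc2nnc(-c3ccncc3)o2)cc1`: 16800 nM
Compound 3, `O=C(CSc1nnc(-c2ccncc2)o1)N/N=C/c1cc(Cl)ccc1O`: 5240 nM

These three share one core and differ only in the aryl group on the carbon with a double bond to nitrogen. In a functional assay on SW 1116 cells (Homo sapiens) for cytotoxicity, read by MTT assay, with a stated time of 48 h (on this read-out lower numbers stand for stronger inhibition and higher numbers for weaker inhibition), compound 3 gives the lowest number of the three: the change from compound 1 to compound 3 is a 2.3-fold lower number from compound 1 to compound 3 (0.37 log units; beyond the scatter), and from compound 2 to compound 3 it is a 3.2-fold lower number from compound 2 to compound 3 (0.51 log units; beyond the scatter), both beyond the scatter, while a 1.4-fold higher number from compound 1 to compound 2 (0.14 log units; within the scatter) lies within it.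

Compound 4, `O=C(CSc1nnc(-c2ccncc2)o1)N/N=C/c1cccs1`, has not yet been measured. Its structural change from compound 3 is thiophen-2-yl in place of 5-chloro-2-hydroxyphenyl on a carbon with a double bond to nitrogen. As far as these compounds go, the two steps into compound 3 show that the 5-chloro-2-hydroxyphenyl group gives a lower number than either 4-hydroxyphenyl or 4-methylphenyl; none of the steps shows a thiophen-2-yl group, so its effect is unknown. Since the 5-chloro-2-hydroxyphenyl leaves, compound 4 is expected to return toward the level of compounds 1 and 2. For compound 4 the estimate means a 2.3-fold higher number from compound 3 to compound 4 (0.36 log units; beyond the scatter). In this assay compound 4 is expected to give about 12000 nM, within a range from 5000 nM to 30000 nM.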

Compound 4, half-maximal inhibitory concentration: 24900 nM
Estimate against measurement, compound 4: 2.1-fold (0.32 log units) below, within the range that was stated.
By their numbers in this assay, from the lowest: compound 3; then compounds 1, 2 and 4 (each within the scatter of the next, the first and the last beyond it).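

In this assay the thiophen-2-yl group in place of 5-chloro-2-hydroxyphenyl gives a 4.8-fold higher number from compound 3 to compound 4 (0.68 log units; beyond the scatter) and this is the largest step yet at this position. Against the other two groups the five-membered ring reads differently: 4-methylphenyl gives way to it with a 1.5-fold higher number from compound 2 to compound 4 (0.17 log units; within the scatter) and no separation beyond the scatter, while 4-hydroxyphenyl gives way to it with a 2.0-fold higher number from compound 1 to compound 4 (0.31 log units; beyond the scatter) and a separation beyond the scatter, so compound 3 now stands apart from all three other aryl groups, with the step from compound 1 the only other one among the new steps to pass the scatter. Nothing measured here accounts for these differences.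

The compounds shown do not separate the chlorine from the hydroxy of 5-chloro-2-hydroxyphenyl. As far as these compounds go, how an amine or a carboxylic acid on the aryl group, or a longer chain in its place, would read in this assay also remains open.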